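The source may report more compounds than this note shows. Statements on the series, on what has been measured and on what is new or still open speak of the compounds shown alone.

Three compounds share one core and differ only in the benzyl group on the piperazine nitrogen. Compound 1 `Cc1cccc(CN2CCN(C(=O)CN[C@H]3CCN(S(=O)(=O)Cc4ccccc4)C3)CC2)c1` carries a 3-methylphenyl there; in a functional assay on K562 cells (Homo sapiens) for cytotoxicity, read by MTT assay, with a stated time of 48 h (a lower number here means a stronger inhibitor, a higher number a weaker inhibitor), compound 1 gives 11300 nM. Compound 2 `O=C(CN[C@H]1CCN(S(=O)(=O)Cc2ccccc2)C1)N1CCN(Cc2cccc(Cl)c2)CC1` carries a 3-chlorophenyl and gives 8600 nM in this assay, while compound 3 `O=C(CN[C@H]1CCN(S(=O)(=O)Cc2ccccc2)C1)N1CCN(Cc2ccc(F)cc2)CC1` carries a 4-fluorophenyl and gives 14300 nM. Compound 2 holds the lowest of the three numbers, but the separations are small: a 1.3-fold lower number from compound 1 to compound 2 (0.12 log units; within the scatter) and a 1.7-fold higher number from compound 2 to compound 3 (0.22 log units; within the scatter), and likewise a 1.3-fold higher number from compound 1 to compound 3 (0.10 log units; within the scatter).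

Compound 4 `COc1cccc(CN2CCN(C(=O)CN[C@H]3CCN(S(=O)(=O)Cc4ccccc4)C3)CC2)c1` has not yet been measured. Its difference from compound 2 is methoxy in place of chloro on an aromatic carbon. The measured step that bears most directly on this change is a 1.3-fold lower number from compound 1 to compound 2 (0.12 log units; within the scatter), a swap of one small group for another on the same aromatic carbon that left the number within the scatter. The two ring swaps, a 1.7-fold higher number from compound 2 to compound 3 (0.22 log units; within the scatter) and a 1.3-fold higher number from compound 1 to compound 3 (0.10 log units; within the scatter), were also within the scatter. Within the data shown here, nothing among the measured compounds therefore points to a step beyond the scatter in this assay in either direction, and the methoxy group itself has no precedent in this set.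

Compound 4 is accordingly expected to give about 10000 nM in this assay, with a range from 5000 nM to 20000 nM. The expected step is a 1.2-fold higher number from compound 2 to compound 4 (0.07 log units; within the scatter).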

Compound 4, half-maximal inhibitory concentration: 60800 nM
For compound 4 the middle estimate is 6.1-fold (0.78 log units) below the measured one; measured number above the stated range.
By their numbers in this assay, from the lowest: compounds 2, 1 and 3 (each within the scatter of the next); then compound 4.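

In this assay, among these compounds, the benzyl group had so far seemed to tolerate any change, but 3-methoxybenzyl is the first group here to stand apart from the others, with a 7.1-fold higher number from compound 2 to compound 4 (0.85 log units; beyond the scatter) and a 5.4-fold higher number from compound 1 to compound 4 (0.73 log units; beyond the scatter) and a 4.3-fold higher number from compound 3 to compound 4 (0.63 log units; beyond the scatter) as well. The two swaps on the same aromatic carbon therefore do not behave alike: chloro in place of methyl stayed within the scatter, whereas methoxy in place of either one gives a step beyond it, so this place does respond to what it carries, although among these four compounds only compound 4 shows that response. Nothing given here explains why methoxy differs from the chloro and methyl groups it replaces.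

The compounds shown leave open whether this step is particular to methoxy or would also appear with a hydroxyl, an ethoxy group or an amine on the same aromatic carbon. Among the compounds shown here, they also leave open whether methoxy would give a similar step at another carbon of that ring, since compound 4 is the only compound here that carries it.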